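The source may report more compounds than this note shows. Statements on the series, on what has been measured and on what is new or still open speak of the compounds shown alone.

Compound 1 `CNC(=O)c1cc(-c2cnc(NCc3c(F)ccc4c3CCO4)c3cn[nH]c(=O)c23)n(C)n1` is the reference point of this pair. In an ADME assay on microsomes from liver (Homo sapiens) for metabolic stability, read by LC-MS, using NADPH, with stated times of 5 min and 30 min, tested at 1 uM (on this read-out lower numbers stand for slow clearance and higher numbers for fast clearance), compound 1 gives < 3 mL.min-1.g-1, which is a limit of the assay and not a number. The other two measured members of the series carry numbers: compound 2 `Cc1ncccc1-c1cnc(NCc2c(F)ccc3c2CCO3)c2ncc(=O)[nH]c12` gives 21 mL.min-1.g-1 in this assay, and compound 3 `O=C1Oc2ccccc2CN1c1cnc(NCc2c(F)ccc3c2CCO3)n2cnnc12` gives 24 mL.min-1.g-1 in this assay. Compound 1 thus sits at the limit of < 3 mL.min-1.g-1 in this assay, at which 1 of the 3 values shown sits, the only one of the three to do so.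

Compound 4 `Cc1ncc(-c2cnc(NCc3c(F)ccc4c3CCO4)c3cn[nH]c(=O)c23)n1C` has not yet been measured. It differs from compound 1 in one place: 1,2-dimethyl-1H-imidazol-5-yl in place of 1-methyl-3-(methylcarbamoyl)-1H-pyrazol-5-yl on an aromatic carbon. Within the data shown here, no pair of measured compounds shares this change, so the size of the step cannot be read from the series itself. The expected step from compound 1 to compound 4 in this assay is an at least 3.3-fold higher number from compound 1 to compound 4 (0.52 log units; beyond the scatter), upward and beyond the scatter. The expectation rests on compound 2 with 21 mL.min-1.g-1 and compound 3 with 24 mL.min-1.g-1, which show where numbers in this series have landed. Compound 4 is estimated at 10 mL.min-1.g-1, with a range from 3 mL.min-1.g-1 to 30 mL.min-1.g-1.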

Compound 4, intrinsic clearance in microsomes: 10 mL.min-1.g-1
Compound 4: the middle estimate sits on the measured number at the digits printed, within the range that was stated.
By their numbers in this assay, from the lowest: compound 4; then compounds 2 and 3 (each within the scatter of the next). At a limit, below all of these: compound 1.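

Exchanging 1-methyl-3-(methylcarbamoyl)-1H-pyrazol-5-yl for 1,2-dimethyl-1H-imidazol-5-yl on this aromatic carbon gives, in this assay, an at least 3.3-fold higher number from compound 1 to compound 4 (0.52 log units; beyond the scatter). Among these compounds, this is the only step that rests on a single change, so it shows what compounds 2 and 3 could not: with the core of compound 1 held fixed, this position alone can move the clearance read-out beyond the scatter. The size of the step is only a lower bound, since compound 1 stands at a limit of the assay: the limit of < 3 mL.min-1.g-1 in this assay, at which 1 of the 4 values shown sits.

The methylcarbamoyl group leaves and the ring changes in the same step, and the compounds shown do not separate the two. Also open, from the compounds shown here alone, is where a carboxylic acid or a morpholine at this position would fall in this assay.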